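Shortening the acyl chain on the shared core

This account rests on a few compounds, and the source may have more. Where it says the series, first, only, none or still open, it means among the compounds named here.

Compound 1, `CC(=O)N1c2ccccc2CCC1C(=O)Nc1cc(C(F)(F)F)cc(C(F)(F)F)c1`: > 70000 nM in a functional assay on NCI-H23 cells (Homo sapiens) for cytotoxicity, read by sulforhodamine B assay, with a stated time of 72 h; on this read-out higher numbers stand for weaker inhibition of growth and lower numbers for stronger inhibition of growth
Compound 2, `CCCCCCCCC(=O)N1c2ccccc2CCC1C(=O)Nc1ccccc1C(F)(F)F`: 4220 nM in this assay

Of the compounds shown here, two built on the shared core have been measured in this assay. For compound 1 the value > 70000 nM is a limit of the assay, not a number (the limit of > 70000 nM in this assay, at which 1 of the 2 values shown sits). Among the measured compounds shown here, compound 2 is therefore the only one with a measured number, 4220 nM, and it stands alone among the values shown; the two compounds differ in more than one place, so their values are simply recorded side by side.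

Compound 3, `CCC(=O)N1c2ccccc2CCC1C(=O)Nc1ccccc1C(F)(F)F`, is not yet measured. It differs from compound 2 by hydrogen in place of hexyl on a saturated chain carbon, two bonds along the chain from a carbonyl carbon, so that the nonanoyl group of compound 2 becomes a propanoyl group.

For the measured compounds named here, no measured step describes this change. Removing a large part of the acyl chain is expected to weaken growth inhibition; the estimated step of a 4.7-fold higher number from compound 2 to compound 3 (0.68 log units; beyond the scatter) is expected to lie beyond the usual scatter. Compound 3 is accordingly estimated at 20000 nM, between 5000 nM and 70000 nM.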

Compound 3, concentration for 50% growth inhibition: > 80000 nM
Compound 3: a limit, no number; the forecaster's own chance of this, stated with the estimate: 30%; middle value at least 4.0-fold (0.60 log units) from the limit.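

In this assay, among the compounds shown here, hydrogen in place of hexyl on a saturated chain carbon, two bonds along the chain from a carbonyl carbon, gives the first step that can be read at this position: an at least 18-fold higher number from compound 2 to compound 3 (1.27 log units; beyond the scatter). From the compounds shown here alone, compound 3 stands at a limit of the assay and has no number, so the step gives only a smallest size and its full size stays unknown: the limit of > 80000 nM in this assay, at which 1 of the 3 values shown sits. Within this pair, the measurable growth inhibition goes with the nonanoyl group of compound 2, and with the propanoyl group of compound 3 no number remains, something the earlier pair, which differed in more than one place, could not show.

The compounds shown leave open how growth inhibition runs across chains of intermediate length, such as a hexanoyl group, and whether a chain longer than nonanoyl would give a lower number. They also leave open whether an amine or a carboxylic acid at the end of the chain would keep the effect, and they give no reason for its loss.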